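Pyridine for cyclohexyl on a cyanoguanidine H2 antagonist

The source may report more compounds than this note shows. Statements on the series, on what has been measured and on what is new or still open speak of the compounds shown alone.

The series shares a cyanoguanidine core with two chains on its nitrogens. In an in vitro functional assay on Sf9 cells for antagonist activity at histamine H2 receptor (Homo sapiens) (on this read-out lower numbers stand for lower potency and higher numbers for higher potency (the scale is a negative logarithm)), compound 1 `N#C/N=C(\NCCCc1ccccc1)NCCCc1c[nH]cn1`, which carries a phenyl-terminated chain, gives 5.25. Compound 2 `N#C/N=C(/NCCCc1c[nH]cn1)NCCCC1CCCCC1` reaches only a limit of the assay in this assay, < 5; < 5 (2 entries). Compound 3 `N#C/N=C(/NCCCCc1c[nH]cn1)NCCCC1CCCCC1` likewise sits at a limit of the assay in this assay, < 5, so no single number places it; it is one of the values that share (the limit of < 5 in this assay, at which 1 of the 3 values shown sits).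

Compound 4 `N#C/N=C(/NCCCCc1c[nH]cn1)NCCCc1ccncc1` differs from compound 3 in one place: pyridin-4-yl in place of cyclohexyl on a saturated chain carbon, three bonds along the chain from an amine nitrogen. No measured step with this exact change exists among the compounds shown, so the expectation rests on compound 1, whose aromatic ring on the shorter chain gave a numerical value, 5.25, where the cyclohexyl compounds gave none. The step is therefore expected to be upward and of a size beyond the scatter, a number at least 0.40 log units higher from compound 3 to compound 4 (beyond the scatter). Compound 4 is estimated to reach 5.4 in this assay, within a range from 4.7 to 6.1.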

Compound 4, negative logarithm of the antagonist equilibrium constant: 5.11
Estimate against measurement, compound 4: 0.29 log units above, within the range that was stated.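

With pyridin-4-yl in place of cyclohexyl on a saturated chain carbon, three bonds along the chain from an amine nitrogen, compound 4 gives a number in this assay, which the cyclohexyl compound on the same chain did not. Read as a step, the change gives a number at least 0.11 log units higher from compound 3 to compound 4 (that floor lies within the scatter), so the data show a measurable value but not the true size of the gain. Compound 3 stands at a limit of the assay, and that limit sets the floor of the step: the limit of < 5 in this assay, at which 1 of the 4 values shown sits.

On these data alone, whether the ring nitrogen of pyridin-4-yl matters remains open, as phenyl appears only in compound 1, which differs from compound 4 in more than one place. Also open, as far as these compounds go, is how pyridin-3-yl, pyridin-2-yl or a terminal amine would read at this position.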